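The source may report more compounds than this note shows. Statements on the series, on what has been measured and on what is new or still open speak of the compounds shown alone.

Series notes, step from compound 3 to compound 4.

Three compounds carry numbers in a physicochemical assay for lipophilicity; a lower number here means a more polar compound, a higher number a more lipophilic compound. Compound 1 `Cc1ccc(NC(=O)CC(CCN)c2nnc(CCCC(C)C)n2C2CC2)c(C)c1` gives 3.1 in this assay. Among the measured compounds shown here, compound 2 `Cc1ccc(NC(=O)CC(CCC(=O)N(C)C)c2nnc(CCCC(C)C)n2C2CC2)c(C)c1` gives 3.8 in this assay, and the only single-point step measured so far is a number 0.70 log units higher from compound 1 to compound 2 (beyond the scatter). Compound 3 `Cc1ccc(NC(=O)C[C@H](CCC(=O)O)c2noc(-c3ccc(CC(C)C)cc3)c2C2CC2)c(Cl)c1` gives 4.8 in this assay, the highest of the three numbers; compound 2 sits nearest to it and compound 1 furthest, both clearly separated from it.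

Compound 4 `Cc1ccc(NC(=O)C[C@H](CCC(=O)O)c2noc(-c3cc(CC(C)(C)C)on3)c2C2CC2)c(Cl)c1` has not yet been measured in this assay. It differs from compound 3 in one place: 5-neopentyl-1,2-oxazol-3-yl in place of 4-isobutylphenyl on an aromatic carbon. For the measured compounds named here, the one measured step, from compound 1 to compound 2, concerns a group on a saturated chain carbon and does not cover an exchange of one aromatic ring for another, so it gives no direct guide here. The change itself replaces a six-membered aromatic ring of carbon only with a five-membered aromatic ring with 2 hetero atoms and 2 hydrogen-bond acceptors, while the attached chain grows from isobutyl to neopentyl. On that basis compound 4 is expected to come out somewhat lower than compound 3, a step of a number 0.40 log units lower from compound 3 to compound 4 (beyond the scatter), with the net effect uncertain in size. The estimate for compound 4 in this assay is 4.4, expected between 3.7 and 5.1.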

Compound 4, distribution coefficient: 4.2
Compound 4: the middle estimate sits 0.20 log units above what was measured, and the stated range covers the measured number.
By their numbers in this assay, from the lowest: compound 1; then compound 2; then compound 4; then compound 3.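

In this assay, among the compounds shown here, the first reading on an aromatic carbon of a five-membered aromatic ring with 1 nitrogen and 1 oxygen, next to the ring oxygen and next to the ring atom that bears a cyclopropyl group, is a number 0.60 log units lower from compound 3 to compound 4 (beyond the scatter) for 5-neopentyl-1,2-oxazol-3-yl in place of 4-isobutylphenyl. For the compounds shown here, the only earlier step concerned a saturated chain carbon, so this is the first measured exchange of one aromatic ring for another, and it holds at 10 heavy atoms on both sides, with 0 hydrogen-bond donors and no net charge, while the entering group has 8 carbon, 1 nitrogen, 1 oxygen and 2 hydrogen-bond acceptors. Nothing measured alongside this result bears on what lies behind the step.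

The ring and the attached chain change together here, so the shares of the two remain unseparated, and a 4-neopentylphenyl group or a 5-isobutyl-1,2-oxazol-3-yl group at this position would divide them. From the compounds shown here alone, whether a step of this size holds with an amine or a dimethylcarbamoyl group in place of the carboxylic acid on the chain also stays open.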